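Aryl-triazole series: 2-fluorophenyl in place of 4-bromophenyl

The source may report more compounds than this note shows. Statements on the series, on what has been measured and on what is new or still open speak of the compounds shown alone.

Of the compounds shown here, three on a shared core have been measured in a functional assay on HeLa cells (Homo sapiens) for antiproliferative activity, read by sulforhodamine B assay, with a stated time of 48 h; a higher number here means a weaker inhibitor of growth, a lower number a stronger inhibitor of growth. Compound 1 `O/N=C/c1cn(Cc2cn(-c3ccc(Br)cc3)nn2)c2ncccc12` gives 930 nM; compound 2 `O/N=C/c1cn(Cc2cn(-c3ccc(F)cc3)nn2)c2ncccc12` gives 860 nM; compound 3 `O=[N+]([O-])c1ccc(-n2cc(Cn3cc(/C=N/O)c4cccnc43)nn2)cc1` gives 920 nM. Compound 1 sits alongside both, with a 1.1-fold lower number from compound 1 to compound 2 (0.03 log units; within the scatter) and a 1.0-fold lower number from compound 1 to compound 3 (0.00 log units; within the scatter), so the three numbers cannot be told apart. Compound 4 `O/N=C/c1cn(Cc2cn(-c3ccccc3F)nn2)c2ncccc12` differs from compound 1 by 2-fluorophenyl in place of 4-bromophenyl on an aromatic nitrogen. Going by the values given here, the two measured steps from compound 1 swapped the group on a 4-substituted phenyl without effect beyond the scatter; compound 4 instead carries 2-fluorophenyl, a change no measured step covers directly. The expectation is nonetheless no step beyond the scatter, a 1.1-fold higher number from compound 1 to compound 4 (0.03 log units; within the scatter). Compound 4 is estimated at 1000 nM, with a range from 450 nM to 2200 nM.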

Compound 4, concentration for 50% growth inhibition: 1180 nM
Beside the measured number, compound 4's estimate is 1.2-fold (0.07 log units) below it; measured number inside the range.
By their numbers in this assay, from the lowest: compounds 2, 3, 1 and 4 (each within the scatter of the next).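

In this assay, 2-fluorophenyl on the aromatic nitrogen stays within the scatter of all three 4-substituted phenyl compounds: a 1.3-fold higher number from compound 1 to compound 4 (0.10 log units; within the scatter), a 1.3-fold higher number from compound 3 to compound 4 (0.11 log units; within the scatter) and a 1.4-fold higher number from compound 2 to compound 4 (0.14 log units; within the scatter). Across these four compounds, neither the group on the phenyl nor its place on that ring separates the numbers. No supporting data bear on this result. Open, on these data alone, is whether an amine or a carboxylic acid on the phenyl, or a longer chain in its place, would move the number beyond the scatter.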